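Swapping 3-hydroxyphenyl for propyl on a ring carbon

A few compounds are considered here, and "the series" means these few. Any claim that something is new, unique, unknown or untested is made for them only; others in the source may bear on it.

Three compounds have values so far in a physicochemical assay for lipophilicity, measured as octanol-water partition (on this read-out higher numbers stand for higher lipophilicity and lower numbers for lower lipophilicity), for comparison:
Compound 1 `CC1=C(C(=O)OCc2cccnc2)C(c2ccco2)C2=C(CCCC2=O)N1` gives 1.03 here
Compound 2 `CC1=C(C(=O)OCc2cccnc2)C(c2ccc(C#N)cc2)C2=C(CCCC2=O)N1` gives 1.36 here
Compound 3 `CC1=C(C(=O)OCc2ccccn2)C(c2cccc(O)c2)C2=C(CCCC2=O)N1` gives 1.58 here

The starting point is compound 3, whose number lies within the usual scatter of repeat measurements of compound 2 and clearly higher than that of compound 1. Moving to compound 4 `CCCC1C(C(=O)OCc2ccccn2)=C(C)NC2=C1C(=O)CCC2` puts propyl in place of 3-hydroxyphenyl on a saturated ring carbon. Among the compounds with values here, only one measured step changes the group on this carbon (a number 0.33 log units higher from compound 1 to compound 2 (beyond the scatter)), and it is modest, with 4-cyanophenyl in place of furan-2-yl. Within the data shown here, no measured step involves propyl, so that modest size is the only guide, and a shift in this assay no larger than the scatter is expected. The expected step is small and upward (a number 0.12 log units higher from compound 3 to compound 4 (within the scatter)), staying within the scatter. For compound 4 the estimated value is 1.7 with an expected range from 1.2 to 2.2 in this measurement.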

Compound 4, partition coefficient: 2.6
Beside the measured number, compound 4's estimate is 0.90 log units below it, and the stated range ends below it.
By their numbers in this assay, from the lowest: compound 1; then compounds 2 and 3 (each within the scatter of the next); then compound 4.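

In this assay, within the data shown here, the change gives a number 1.02 log units higher from compound 3 to compound 4 (beyond the scatter), a large step that far exceeds the only earlier change on this saturated ring carbon, a number 0.33 log units higher from compound 1 to compound 2 (beyond the scatter). Among these compounds, the number can therefore move much further with the group on this carbon than the earlier swap between two ring-bearing groups showed, and compound 4 is the first here to carry an open chain with no ring and no hydrogen-bond donor or acceptor on that carbon. Nothing available accounts for the size of this step.

Because the ring, the hydroxyl and several heavy atoms all leave together, the compounds shown cannot separate what each loss contributes. A plain phenyl group on this carbon would isolate the hydroxyl, while a longer chain such as pentyl would test how the number follows chain length.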